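One Hydroxyphenyl Swap, Seen on Two Cores

A few compounds are considered here, and "the series" means these few. Any claim that something is new, unique, unknown or untested is made for them only; others in the source may bear on it.

Compound 1 `O=C(/C=C/c1ccccc1O)CC(=O)/C=C/c1cc(O)ccc1O` and compound 2 `O=C(/C=C/c1cccc(O)c1)CC(=O)/C=C/c1cc(O)ccc1O` share a core and differ in a single group: 3-hydroxyphenyl in place of 2-hydroxyphenyl on a double-bonded chain carbon bound to a double-bonded chain carbon. In a functional assay, with a stated time of 30 min (a higher number here means a weaker inhibitor, a lower number a stronger inhibitor), compound 1 gives 48000 nM and compound 2 gives 88000 nM, so the swap made a 1.8-fold higher number from compound 1 to compound 2 (0.26 log units; within the scatter). Compound 3 `O=C(/C=C/c1ccccc1O)/C=C/c1cccc(O)c1O` rests on a different core; how its core differs from the core of compound 1 is not broken down here. In this assay compound 3 gives 99000 nM, which lies close to the number of compound 2 and beyond the usual scatter only against compound 1. Compound 4 `O=C(/C=C/c1cccc(O)c1)/C=C/c1cccc(O)c1O` has not yet been measured. Relative to compound 3 it carries exactly the change that compound 2 carries relative to compound 1: 3-hydroxyphenyl in place of 2-hydroxyphenyl on a double-bonded chain carbon bound to a double-bonded chain carbon. The group that leaves and the group that enters sit in the same place on both cores, so this is the same change, made twice. The earlier swap gave a 1.8-fold higher number from compound 1 to compound 2 (0.26 log units; within the scatter). The step is expected to be of similar size, namely a 1.5-fold higher number from compound 3 to compound 4 (0.18 log units; within the scatter). In this assay compound 4 is therefore estimated at 150000 nM, most likely between 70000 nM and 350000 nM.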

Compound 4, half-maximal inhibitory concentration: 48000 nM
For compound 4 the middle estimate is 3.1-fold (0.49 log units) above the measured one; measured number below the stated range.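

On the core of compound 3, putting 3-hydroxyphenyl in place of 2-hydroxyphenyl gives, in this assay, a 2.1-fold lower number from compound 3 to compound 4 (0.31 log units; beyond the scatter). This shows that, in this series, the result of the swap on one core did not carry over to the other, so a step read on the core of compound 1 was a poor guide on the core of compound 3. It rests on just two pairs of compounds, however, and does not show why the cores part ways or how the swap would behave on any third core, but the gap between the two steps is clear: the same change on two cores in this assay, a 1.8-fold higher number (0.26 log units; within the scatter) from compound 1 to compound 2 and a 2.1-fold lower number (0.31 log units; beyond the scatter) from compound 3 to compound 4, 3.8-fold (0.58 log units) apart, beyond the scatter of two such steps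

From the compounds shown here alone, the cores of compound 1 and compound 3 differ by more than one feature, so it remains open which part of the core decides how the swap turns out. Also open, going by these compounds, is whether an amine or a carboxylic acid in place of the hydroxyl group on this phenyl ring would respond to the two cores in the same way or differently.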